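Compound 3 against the assay limit

The source may hold more compounds than are shown below. What is called first, only, known or untested is meant among the compounds shown, and "the series" means these compounds.

Measured so far:
- Compound 1 `Nc1ncc(-c2ccncc2)cn1`: > 100000 nM (a limit)
- Compound 2 `Nc1ncc(-c2ccncc2)c(C2CCC2)n1`: > 100000 nM (a limit)

In a functional assay on CUTLL1 cells (Homo sapiens) for inhibition, read by resazurin assay, with a stated time of 48 h, in the absence of a further agent (on this read-out higher numbers stand for an effect only at larger amounts of compound and lower numbers for an effect already at smaller amounts), compound 2 gives no number, only the limit > 100000 nM. The same holds for the whole set so far: the limit of > 100000 nM in this assay, at which 2 of the 2 values shown sit.

The next compound is compound 3 `Nc1ncc(-c2ccncc2)c(-c2ccccc2)n1`, with phenyl in place of cyclobutyl on an aromatic carbon. The rest of the structure of compound 2 is kept.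

Among the measured compounds shown here, one measured step bears on this change, a step that the two limits leave unreadable from compound 1 to compound 2. It has no readable size and supplies neither a magnitude nor a direction to carry over. For the measured compounds named here, no measured compound yet gives a number in this assay, so the expectation is that compound 3 stays close to the limit, with a report of the limit alone the likeliest outcome.

The expected change is an at least 1.1-fold lower number from compound 2 to compound 3 (0.04 log units; that floor lies within the scatter), which is only a loose estimate. For compound 3 the estimated value is 90000 nM, with an expected range from 25000 nM to 150000 nM.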

Compound 3, half-maximal effective concentration: > 100000 nM
Compound 3: a limit, no number; the forecaster's own chance of this, stated with the estimate: 65%; at least 1.1-fold (0.04 log units) between middle value and limit.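

In this assay compound 3 gives > 100000 nM, a limit and not a number. No step among compound 1, compound 2 and compound 3 can be read, because all three sit at the same limit: the limit of > 100000 nM in this assay, at which 3 of the 3 values shown sit.

The compounds shown leave open how cyclobutyl, phenyl and hydrogen compare in this assay, and whether any change to the shared core gives a readable number.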